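The source may hold more compounds than are shown below. What is called first, only, known or untested is meant among the compounds shown, and "the series" means these compounds.

Measured so far, in a functional assay on AGS cells (Homo sapiens) for antiproliferative activity, read by CCK-8 assay, with a stated time of 72 h; a lower number here means a stronger inhibitor, a higher number a weaker inhibitor:
- compound 1 `CC(=O)N1CC=C(c2ccn3c(-c4ccc(NC(=O)c5ccc([N+](=O)[O-])o5)cc4)cnc3c2)CC1` gives 410 nM
- compound 2 `O=C(Nc1ccc(-c2cnc3cc(N4CCN(C5CC5)CC4)ccn23)cc1)c1ccc([N+](=O)[O-])o1` gives 1920 nM
- compound 3 `CC1(O)CCN(c2ccn3c(-c4ccc(NC(=O)c5ccc([N+](=O)[O-])o5)cc4)cnc3c2)CC1` gives 1530 nM

Compound 1 holds the lowest number of the three, with compound 3 nearest and compound 2 furthest. Compound 4 `O=C(Nc1ccc(-c2cnc3ccccn23)cc1)c1ccc([N+](=O)[O-])o1` differs from compound 1 in one place: a hydrogen atom in place of a group of 9 heavy atoms (7 carbon, 1 nitrogen, 1 oxygen; one six-membered non-aromatic ring with 1 hetero atom), on an aromatic carbon. Among the measured compounds shown here, two measured steps bear on this, since both replace the same group on the same aromatic carbon: a 4.7-fold higher number from compound 1 to compound 2 (0.67 log units; beyond the scatter) and a 3.7-fold higher number from compound 1 to compound 3 (0.57 log units; beyond the scatter). Each exchange of that group raised the number modestly and beyond the scatter. Removing the group altogether is expected to move in the same direction, likely by a similar or somewhat larger step, estimated as a 7.3-fold higher number from compound 1 to compound 4 (0.86 log units; beyond the scatter). Compound 4 is therefore expected to give about 3000 nM, within a range of 900 nM to 10000 nM.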

Compound 4, half-maximal inhibitory concentration: 360 nM
Estimate against measurement, compound 4: 8.3-fold (0.92 log units) above, outside the stated range (below it).
By their numbers in this assay, from the lowest: compounds 4 and 1 (each within the scatter of the next); then compounds 3 and 2 (each within the scatter of the next).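

In this assay this aromatic carbon opposite the ring nitrogen needs no substituent to reach the low numbers, since hydrogen in place of the group of compound 1 gives a 1.1-fold lower number from compound 1 to compound 4 (0.06 log units; within the scatter) and so stays within the scatter. The higher numbers thus belong to 4-hydroxy-4-methylpiperidin-1-yl and 4-cyclopropylpiperazin-1-yl, with a 4.3-fold lower number from compound 3 to compound 4 (0.63 log units; beyond the scatter) and a 5.3-fold lower number from compound 2 to compound 4 (0.73 log units; beyond the scatter) on replacing them by hydrogen. No measurement at hand explains this difference between the groups.

On these data alone, whether a small group such as methoxy or a primary amine on this carbon would fall with compound 4 and compound 1 or with compound 3 and compound 2 remains open.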